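Amine Ring Size Across Two Closely Related Pairs

The compounds below may be only part of what the source reports. "The series", "measured", "known", "first", "only" and "open" are said of these compounds alone.

Of the compounds shown here, three have so far been measured in a functional assay on A-431 cells (Homo sapiens) for inhibition, with a stated time of 72 h; a higher number here means a weaker inhibitor, a lower number a stronger inhibitor. Compound 1 `Oc1c(CN2CCCC2)ccc2cccnc12` gives 16600 nM. Compound 2 `Oc1c(CN2CCCCC2)ccc2cccnc12` carries piperidin-1-yl in place of pyrrolidin-1-yl on a saturated chain carbon bound to an aromatic carbon and gives 9770 nM in this assay; the step is a 1.7-fold lower number from compound 1 to compound 2 (0.23 log units; within the scatter). Compound 3 `COCc1cc(CN2CCCC2)c(O)c2ncccc12` differs from compound 1 in that it carries methoxymethyl in place of hydrogen on an aromatic carbon; in this assay compound 3 gives 52500 nM, the highest number of the three, and the step is a 3.2-fold higher number from compound 1 to compound 3 (0.50 log units; beyond the scatter). The numbers for compound 1 and compound 2 lie within the scatter of each other, so no order between them is claimed.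

Compound 4 `COCc1cc(CN2CCCCC2)c(O)c2ncccc12` has not yet been measured in this assay. Among the compounds with values here, it differs from compound 3 by piperidin-1-yl in place of pyrrolidin-1-yl on a saturated chain carbon bound to an aromatic carbon, which is the same change as the one between compound 1 and compound 2, here made on the core that also carries the methoxymethyl group. That change has been seen only once, so its size rests on a single pair. Because the earlier step was a 1.7-fold lower number from compound 1 to compound 2 (0.23 log units; within the scatter), a step of similar size is expected, and an estimated step of a 1.7-fold lower number from compound 3 to compound 4 (0.23 log units; within the scatter) is taken here. Compound 4 is accordingly estimated at 31000 nM in this assay, with a likely range from 15000 nM to 80000 nM allowing for the scatter of such measurements.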

Compound 4, half-maximal inhibitory concentration: 22400 nM
Beside the measured number, compound 4's estimate is 1.4-fold (0.14 log units) above it, and the stated range covers the measured number.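

In this assay, replacing pyrrolidin-1-yl with piperidin-1-yl on the core bearing methoxymethyl gives a 2.3-fold lower number from compound 3 to compound 4 (0.37 log units; beyond the scatter), and this step agrees with the one seen on the core of compound 1: the same change on two cores in this assay, a 1.7-fold lower number (0.23 log units; within the scatter) from compound 1 to compound 2 and a 2.3-fold lower number (0.37 log units; beyond the scatter) from compound 3 to compound 4, 1.4-fold (0.14 log units) apart, within the scatter of two such steps Read the other way round, adding methoxymethyl to the piperidin-1-yl compound gives a 2.3-fold higher number from compound 2 to compound 4 (0.36 log units; beyond the scatter), which also agrees with the step seen with pyrrolidin-1-yl: the same change on two cores in this assay, a 3.2-fold higher number (0.50 log units; beyond the scatter) from compound 1 to compound 3 and a 2.3-fold higher number (0.36 log units; beyond the scatter) from compound 2 to compound 4, 1.4-fold (0.14 log units) apart, within the scatter of two such steps Within these four compounds, each change therefore carries from one core to the other at a similar size, so the two changes appear to add up, but this rests on a single pair of steps for each change and does not show that the same would hold on any other core or in any other assay.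

Going by these compounds, it remains open whether other cyclic or open-chain amines, such as morpholin-4-yl or dimethylamino, would continue the small step seen from pyrrolidin-1-yl to piperidin-1-yl. On these data alone, it is equally open whether a group such as ethoxymethyl or hydroxymethyl in place of methoxymethyl would give a step of similar size on both cores.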